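This account rests on a few compounds, and the source may have more. Where it says the series, first, only, none or still open, it means among the compounds named here.

Measured so far:
compound 2 `NC1CCN(c2ccc3cc(NC(=O)CCc4ccc(C(F)(F)F)cc4)ccc3n2)C1` — 12 nM in an assay on isolated protein for displacement of a labelled ligand from melanin-concentrating hormone receptor 1 (Homo sapiens); a lower number here means a stronger inhibitor, a higher number a weaker inhibitor
compound 1 `O=C(CCc1ccc(C(F)(F)F)cc1)Nc1ccc2nc(N3CC4CC3CO4)ccc2c1` — 13 nM in this assay

Compound 2 gives the lowest of the two numbers shown, with compound 1 its only neighbour; the two values lie within the scatter of each other, so neither can be called the stronger. Among the measured compounds shown here, the one measured step, a 1.1-fold lower number from compound 1 to compound 2 (0.03 log units; within the scatter), is the only one that bears on the new compound, and it shows that exchanging the whole group on that aromatic carbon leaves the number essentially unchanged. Compound 3 `CNC(=O)NC1CCN(c2ccc3cc(NC(=O)CCc4ccc(C(F)(F)F)cc4)ccc3n2)C1` keeps the pyrrolidine of compound 2 and differs from it by methylcarbamoyl in place of hydrogen on an amine nitrogen, which here reads as amino to (methylcarbamoyl)amino. Since the step from compound 1 to compound 2 was flat, the modest extension in compound 3 is expected to change little, perhaps a small shift toward a higher number: the step is estimated at a 1.7-fold higher number from compound 2 to compound 3 (0.22 log units; within the scatter). Compound 3 is therefore expected at 20 nM, within 6 nM to 70 nM.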

Compound 3, half-maximal inhibitory concentration: 6 nM
Estimate against measurement, compound 3: 3.3-fold (0.52 log units) above; the measured number falls inside the stated range.
By their numbers in this assay, from the lowest: compounds 3, 2 and 1 (each within the scatter of the next, the first and the last beyond it).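

In this assay, the amine nitrogen of the 3-aminopyrrolidin-1-yl group can carry methylcarbamoyl without leaving the scatter, with a 2.0-fold lower number from compound 2 to compound 3 (0.30 log units; within the scatter) as the step, so no gain can be claimed for this change alone. Set against the group of compound 1, however, the 3-((methylcarbamoyl)amino)pyrrolidin-1-yl group gives a 2.2-fold lower number from compound 1 to compound 3 (0.34 log units; beyond the scatter), the only step among these compounds to lie beyond the scatter, and a modest one. Nothing measured here accounts for these numbers.

From the compounds shown here alone, it remains open whether an acetyl or an ethylcarbamoyl group on the same nitrogen would give a similar number. Also open, going by these compounds, is how a much larger group, such as phenylcarbamoyl, would fare at this position.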